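The source may hold more compounds than are shown below. What is called first, only, known or untested is meant among the compounds shown, and "the series" means these compounds.

Compound 3 `CC1CCN(CC(=O)O[C@@H]2C[C@@H]3CC[C@@]2(C)C3(C)C)CC1` is the ester in which a 4-methylpiperidin-1-yl group sits on the saturated chain carbon bound to the carbonyl carbon. Among the compounds with values here, in an ADME assay on MDCK cells (Canis lupus familiaris) for cytotoxicity, read by MTT assay, with a stated time of 48 h (a lower number here means that less compound is tolerated, a higher number that more compound is tolerated), compound 3 gives 93900 nM, the second highest of the three numbers so far. It sits close to compound 2 `CN1CCN(CC(=O)O[C@@H]2C[C@@H]3CC[C@@]2(C)C3(C)C)CC1`, which gives 103000 nM, with a 1.1-fold lower number from compound 2 to compound 3 (0.04 log units; within the scatter). Both stand well apart from compound 1 `CC1(C)[C@H]2CC[C@]1(C)[C@H](OC(=O)CCN1CCNCC1)C2`, which gives 12600 nM; the steps were an 8.2-fold higher number from compound 1 to compound 2 (0.91 log units; beyond the scatter) and a 7.5-fold higher number from compound 1 to compound 3 (0.87 log units; beyond the scatter).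

Compound 4 `CC1(C)[C@H]2CC[C@]1(C)[C@H](OC(=O)CN1CCNCC1)C2` is built from compound 3 by piperazin-1-yl in place of 4-methylpiperidin-1-yl on a saturated chain carbon bound to a carbonyl carbon. Within the data shown here, no measured step isolates this exact change. Compound 1 carries the same ring as compound 4, but as (piperazin-1-yl)methyl rather than piperazin-1-yl, so the step of a 7.5-fold higher number from compound 1 to compound 3 (0.87 log units; beyond the scatter) mixes two changes and cannot be credited to the ring alone. The step of a 1.1-fold lower number from compound 2 to compound 3 (0.04 log units; within the scatter) shows that swapping a 4-methylpiperazin-1-yl for a 4-methylpiperidin-1-yl moved nothing beyond the scatter. Compound 4 shares its ring with compound 1 and its linking group with compounds 2 and 3, so the expected number lies between those two groups of values. Compound 4 is therefore estimated at 40000 nM, within 12000 nM to 120000 nM, an expected step of a 2.3-fold lower number from compound 3 to compound 4 (0.37 log units; beyond the scatter).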

Compound 4, half-maximal cytotoxic concentration: 51600 nM
Compound 4: middle estimate off by 1.3-fold (0.11 log units), on the low side; measured number inside the range.
By their numbers in this assay, from the lowest: compound 1; then compounds 4, 3 and 2 (each within the scatter of the next).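

Within the data shown here, the step of a 4.1-fold higher number from compound 1 to compound 4 (0.61 log units; beyond the scatter) in this assay is the first to keep the ring nitrogen unsubstituted and change only the attachment, with piperazin-1-yl in place of (piperazin-1-yl)methyl on a saturated chain carbon bound to a carbonyl carbon, and it lies beyond the scatter, so this change alone moves the number. The steps of a 1.8-fold lower number from compound 3 to compound 4 (0.26 log units; within the scatter) and a 2.0-fold lower number from compound 2 to compound 4 (0.30 log units; within the scatter) both stay within the scatter, so at this position neither piperazin-1-yl in place of 4-methylpiperidin-1-yl nor hydrogen in place of methyl on the ring amine nitrogen separates these compounds, and among the four only compound 1, with its (piperazin-1-yl)methyl group, stands apart. No measurement shown here explains why the attachment counts for more than the ring.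

The compounds shown leave open whether a still longer chain carrying the piperazine would continue this trend, since only one such extension appears, and whether an open-chain amine such as diethylamino or a morpholin-4-yl ring would stay with compounds 2, 3 and 4. They also leave open whether an ethyl or larger group on the ring nitrogen would remain within the scatter.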